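The source may report more compounds than this note shows. Statements on the series, on what has been measured and on what is new or still open speak of the compounds shown alone.

Measured compounds:
compound 1, `CCCC(O)CC(=O)O[C@H](CC=C(C)C)C1=CC(=O)c2c(O)ccc(O)c2C1=O`, 59300 nM
compound 2, `CC[C@](C)(O)CC(=O)O[C@H](CC=C(C)C)C1=CC(=O)c2c(O)ccc(O)c2C1=O`, 30200 nM
compound 3, `CC(C)=CC[C@@H](OC(=O)CC(O)c1ccccc1)C1=CC(=O)c2c(O)ccc(O)c2C1=O`, 44500 nM

In a functional assay on HeLa cells (Homo sapiens) for cytotoxicity, read by MTT assay (a higher number here means a weaker inhibitor, a lower number a stronger inhibitor), compound 3 stands second highest of the three numbers, yet it lies within the scatter of both others: a 1.3-fold lower number from compound 1 to compound 3 (0.12 log units; within the scatter); a 1.5-fold higher number from compound 2 to compound 3 (0.17 log units; within the scatter). Compound 4, `CC(C)=CC[C@@H](OC(=O)C1CCCOC1)C1=CC(=O)c2c(O)ccc(O)c2C1=O`, is not yet measured. It differs from compound 3 in one place: oxan-3-yl in place of 2-hydroxy-2-phenylethyl on a carbonyl carbon. Within the data shown here, the steps that bear on this change alter the same position, the group on the carbonyl carbon: a 2.0-fold lower number from compound 1 to compound 2 (0.29 log units; within the scatter) and a 1.5-fold higher number from compound 2 to compound 3 (0.17 log units; within the scatter). Neither moved the number beyond the scatter, so no step beyond the scatter is expected in this assay here either. Compound 4 is therefore estimated at 45000 nM, in a range of 15000 nM to 130000 nM, a step of a 1.0-fold higher number from compound 3 to compound 4 (0.00 log units; within the scatter) that is expected to stay within the scatter.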

Compound 4, half-maximal inhibitory concentration: 60500 nM
Compound 4: the middle estimate sits 1.3-fold (0.13 log units) below what was measured; measured number inside the range.
By their numbers in this assay, from the lowest: compounds 2, 3, 1 and 4 (each within the scatter of the next).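

Swapping 2-hydroxy-2-phenylethyl for oxan-3-yl on the carbonyl carbon removes the aromatic ring and the hydrogen-bond donor, yet the step stays within the scatter in this assay (a 1.4-fold higher number from compound 3 to compound 4 (0.13 log units; within the scatter)). The same holds against the two other compounds (a 2.0-fold higher number from compound 2 to compound 4 (0.30 log units; within the scatter); a 1.0-fold higher number from compound 1 to compound 4 (0.01 log units; within the scatter)), so a group without a hydroxy group fits this series of values as well as the three hydroxy-bearing chains. No measurement here accounts for this.

From the compounds shown here alone, whether an amine or a carboxylic acid at this position would move the number beyond the scatter stays open.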